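Aryl exchange on the ring nitrogen in the series

The source may report more compounds than this note shows. Statements on the series, on what has been measured and on what is new or still open speak of the compounds shown alone.

Values in a functional assay on HOS-TE85 cells (Homo sapiens) for inhibition, read by CCK-8 assay, with a stated time of 72 h (a lower number here means a stronger inhibitor, a higher number a weaker inhibitor), for the series
compound 1 `CCN1C(=O)CSC1c1cccc(C(=O)NCCCCc2ccccc2)c1` gives > 1000 nM as a limit of the assay
compound 2 `COc1c(F)cccc1N1C(=O)CSC1c1cccc(C(=O)NCCCCc2ccccc2)c1` gives 26.2 nM as a number
compound 3 `COc1ccc(N2C(=O)CSC2c2cccc(C(=O)NCCCCc3ccccc3)c2)c(OC)c1` gives 90.4 nM as a number

Compound 3 stands highest of the two actual numbers, and compound 1 is reported only as a limit. Its nearest neighbour shows a 3.5-fold higher number from compound 2 to compound 3 (0.54 log units; beyond the scatter) on exchange of the aryl group.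

Compound 4 `O=C(NCCCCc1ccccc1)c1cccc(C2SCC(=O)N2c2ccc(C3CC3)cc2)c1` has not yet been measured. It carries 4-cyclopropylphenyl in place of 2,4-dimethoxyphenyl on an amide-type nitrogen in a ring, and the exchange counts as 4-cyclopropylphenyl in place of 2,4-dimethoxyphenyl on an amide-type nitrogen in a ring in full.

Within the data shown here, three measured steps bear on this place. Replacing ethyl with an aryl group gave an at least 38-fold lower number from compound 1 to compound 2 (1.58 log units; beyond the scatter) and an at least 11-fold lower number from compound 1 to compound 3 (1.04 log units; beyond the scatter) as large changes, both starting from a limit. Exchange between the two aryl groups gave the modest 3.5-fold higher number from compound 2 to compound 3 (0.54 log units; beyond the scatter) as its result. Compound 4 keeps a phenyl ring at this place, so the large gain over ethyl is expected to hold largely intact. Both measured aryl groups carry methoxy and the entering group does not, so a slightly higher number is thought more likely than a lower one. The expected step is a 1.2-fold higher number from compound 3 to compound 4 (0.09 log units; within the scatter) with its size small and its direction uncertain. For compound 4 the estimated value is 110 nM with 30 nM to 400 nM as the expected range.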

Compound 4, half-maximal inhibitory concentration: 217 nM
For compound 4 the middle estimate is 2.0-fold (0.30 log units) below the measured one, within the range that was stated.
By their numbers in this assay, from the lowest: compound 2; then compound 3; then compound 4. At a limit, above all of these: compound 1.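

In this assay, an aryl group on the amide-type nitrogen in a ring that carries neither methoxy nor fluorine still improves on ethyl, with an at least 4.6-fold lower number from compound 1 to compound 4 (0.66 log units; beyond the scatter), so this gain does not depend on either of those groups. Among the aryl groups the spread is wider than compounds 2 and 3 alone showed, with a 2.4-fold higher number from compound 3 to compound 4 (0.38 log units; beyond the scatter) and an 8.3-fold higher number from compound 2 to compound 4 (0.92 log units; beyond the scatter), which places both methoxy-bearing aryl groups at lower numbers than 4-cyclopropylphenyl, and no compound shown goes against that order. Compound 1 is held only as a limit of the assay, so the step from it gives a bound and not a size: the limit of > 1000 nM in this assay, at which 1 of the 4 values shown sits.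

In compound 4 the methoxy groups leave and the cyclopropyl ring enters in a single exchange, so the compounds shown cannot tell which of the two goes with the higher number. Plain phenyl, or phenyl carrying a single methoxy or a morpholine, on this nitrogen remains open, as does whether any aryl group here can reach a number lower than that of compound 2.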